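This account rests on a few compounds, and the source may have more. Where it says the series, first, only, none or still open, it means among the compounds named here.

In a functional assay on NUGC-3 cells (Homo sapiens) for inhibition, read by sulforhodamine B assay, with a stated time of 48 h (on this read-out lower numbers stand for stronger inhibition of growth and higher numbers for weaker inhibition of growth), compound 1 `O=C(Nc1cc(C(F)(F)F)cc(C(F)(F)F)c1)c1nccc2ccccc12` reaches only the limit of the assay, > 10000 nM. Compound 3 `COc1ccc(NC(=O)C2NCCc3ccccc32)cc1` likewise gives only a limit in this assay, > 10000 nM. Among the measured compounds shown here, compound 2 `COc1ccc(NC(=O)C2c3ccccc3CCN2C(=O)c2ccc(Cl)cc2)cc1` is thus the one compound with a number in this assay, 3630 nM.

For the measured compounds named here, the single measured step runs from compound 2 to compound 3, an at least 2.7-fold higher number from compound 2 to compound 3 (0.44 log units; beyond the scatter), and it ends at a limit (the limit of > 10000 nM in this assay, at which 2 of the 3 values shown sit), so its true size is not known. It changes an amine in the ring, not the group on the amide-type nitrogen, and therefore says nothing directly about the change now in question.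

Compound 4 `COc1ccccc1NC(=O)C1c2ccccc2CCN1C(=O)c1ccc(Cl)cc1` differs from compound 2 in one place: 2-methoxyphenyl in place of 4-methoxyphenyl on an amide-type nitrogen. The 4-methoxyphenyl of compound 2 leaves and a 2-methoxyphenyl enters, on an amide-type nitrogen whose other neighbour is the carbonyl carbon. Going by the values given here, no measured step touches this position, so the size and direction of the step can only be guessed from the scatter of the assay and the position of compound 2 close to the limit. The step from compound 2 to compound 4 in this assay is expected to be a 1.4-fold higher number from compound 2 to compound 4 (0.14 log units; within the scatter), within or near the scatter. For compound 4 the estimate in this assay is 5000 nM, ranging from 1500 nM to 15000 nM.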

Compound 4, concentration for 50% growth inhibition: 1590 nM
Beside the measured number, compound 4's estimate is 3.1-fold (0.50 log units) above it, within the range that was stated.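

In this assay, the group on the amide-type nitrogen turns out to matter: exchanging 4-methoxyphenyl for 2-methoxyphenyl gives a 2.3-fold lower number from compound 2 to compound 4 (0.36 log units; beyond the scatter) and so moves growth inhibition beyond the scatter, although the two groups hold the same atoms, joined differently. The earlier compounds shown here showed nothing about this place, and the result gives its first direction, with the lower number and thus the stronger inhibition of growth belonging to the 2-methoxyphenyl group. It also gives the series a second real number, so this change can be sized, whereas the earlier step from the amine ring change could not be, since it ends at a limit: the limit of > 10000 nM in this assay, at which 2 of the 4 values shown sit.

The two compounds compared here show a single exchange on one shared core, so they do not tell why the 2-methoxyphenyl group gives the lower number or whether the gain would persist with a different group on the ring nitrogen in place of (4-chlorophenyl)carbonyl. On these data alone, it also remains open how a 2-hydroxyphenyl, a 2-aminophenyl or a 2-ethoxyphenyl group would behave on the same amide-type nitrogen.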